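Swapping an aryl for a benzyl on a fused bicyclic core

The compounds below may be only part of what the source reports. "The series", "measured", "known", "first", "only" and "open" are said of these compounds alone.

Measured so far:
compound 1 `C=C(Br)C(=O)Nc1cccc(-c2cn3nc(-c4ccc(OCC)cc4)sc3n2)c1`: 790 nM
compound 2 `C=C(Br)C(=O)Nc1cccc(-c2cn3nc(-c4ccc(Cl)cc4)sc3n2)c1`: 1400 nM

Of the compounds shown here, two have been tested in a functional assay on L1210 cells (Mus musculus) for inhibition, read by cell counting, with a stated time of 2 days; on this read-out higher numbers stand for weaker inhibition and lower numbers for stronger inhibition. Compound 1 gives 790 nM, and compound 2 gives 1400 nM. The only difference between them is a chloro in place of an ethoxy on the outer ring, and the step of a 1.8-fold higher number from compound 1 to compound 2 (0.25 log units; within the scatter) stays within the usual scatter, so compound 2 and compound 1 cannot be told apart on these numbers.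

Compound 3 `C=C(Br)C(=O)Nc1cccc(-c2cn3nc(Cc4ccc(OC)cc4)sc3n2)c1` has not yet been measured. It differs from compound 2 in one place: 4-methoxybenzyl in place of 4-chlorophenyl on an aromatic carbon. Among the compounds with values here, no measured step covers the insertion of a methylene between the core and the outer ring; the only step available, a 1.8-fold higher number from compound 1 to compound 2 (0.25 log units; within the scatter), concerns just the substituent on that ring and was within the scatter. On that slim basis no change beyond the scatter is expected in this assay. Compound 3 is therefore estimated at 1000 nM, with a range from 300 nM to 4000 nM. This corresponds to an expected step of a 1.4-fold lower number from compound 2 to compound 3 (0.15 log units; within the scatter).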

Compound 3, half-maximal inhibitory concentration: 1400 nM
Compound 3: the middle estimate sits 1.4-fold (0.15 log units) below what was measured, within the range that was stated.
By their numbers in this assay, from the lowest: compounds 1, 2 and 3 (each within the scatter of the next).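

In this assay, 4-methoxybenzyl in place of 4-chlorophenyl gives no change at the digits printed from compound 2 to compound 3 (within the scatter) and 4-methoxybenzyl in place of 4-ethoxyphenyl gives a 1.8-fold higher number from compound 1 to compound 3 (0.25 log units; within the scatter). The earlier pair differed only in the substituent on the outer ring, whereas compound 3 shows that this ring can also be attached to the aromatic carbon of the five-membered ring through a methylene with no difference that can be read in this assay. Nothing available offers an explanation for this flat result.

As far as these compounds go, compound 3 changes the link and the ring substituent together, so the effect of each alone remains unknown, and two effects that offset each other cannot be told apart from a true absence of effect. From the compounds shown here alone, it also remains open whether an amine or a carboxylic acid on the outer ring, or a longer chain in place of the methylene, would move the number beyond the scatter, so the flat result so far covers only these three neutral-looking variations of one shared core.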